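The source may hold more compounds than are shown below. What is called first, only, known or untested is meant among the compounds shown, and "the series" means these compounds.

Measured in an ADME assay on BJ cells (Homo sapiens) for cytotoxicity, read by luminescence, with a stated time of 72 h; a higher number here means that more compound is needed for the effect, a lower number that less compound is needed:

- Compound 1 `CCOC(=O)c1c(-c2cccc(OC)c2)[nH]c2cc(OC)c(OC)cc2c1=O`: > 21500 nM
- Compound 2 `CCOC(=O)c1c(-c2cccc(Oc3ccccc3)c2)[nH]c2cc(OC)c(OC)cc2c1=O`: > 21500 nM
- Compound 3 `CCOC(=O)c1c(-c2cccc(OC)c2)[nH]c2cc(Cl)c(OC)cc2c1=O`: > 21500 nM

Compound 1 gives > 21500 nM, which is a limit of the assay and not a number. Within the data shown here, compound 2 and compound 3 stop at that same limit, so no measured compound here has a true number to serve as a reference: the limit of > 21500 nM in this assay, at which 3 of the 3 values shown sit.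

The unmeasured compound 4 `CCOC(=O)c1c(-c2cccc(OC)c2)[nH]c2cc(OC)c(F)cc2c1=O` takes compound 1 and swaps one methoxy group of the core for fluoro: fluoro in place of methoxy on an aromatic carbon.

Among the measured compounds shown here, two measured steps bear on this. The closer one is a step that the two limits leave unreadable from compound 1 to compound 3, where chloro takes the place of a methoxy group on an aromatic carbon. The other is a step that the two limits leave unreadable from compound 1 to compound 2, a change at a different methoxy group. Neither has a size that can be read, but neither brought any compound off the limit in this assay. No step in either direction beyond the usual scatter is therefore expected, so the expected change is a step that the limit leaves unreadable from compound 1 to compound 4. Compound 4 will most likely also report only a limit.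

For compound 4 the estimated value is 30000 nM, with an expected range from 15000 nM to 60000 nM.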

Compound 4, half-maximal effective concentration: > 21500 nM
Compound 4 ended at the assay's limit (the forecaster's own chance of this, stated with the estimate: 90%); the middle value does not contradict the limit.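

Among these compounds, compound 4 gives > 21500 nM as a limit of the assay and not a number, so no step from compound 1 to compound 4 can be read: the limit of > 21500 nM in this assay, at which 4 of the 4 values shown sit.

As far as these compounds go, what stays open is how far these compounds lie from that limit, and whether any change on the shared core would give a true number in this assay at all.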